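A few compounds are considered here, and "the series" means these few. Any claim that something is new, unique, unknown or untested is made for them only; others in the source may bear on it.

Values so far in an ADME assay on NIH3T3 cells (Mus musculus) for cytotoxicity; a lower number here means that less compound is tolerated, a higher number that more compound is tolerated
- compound 1 `CCOC(=O)CN(C)CC#Cc1cc2ncnc(Nc3ccc(OCc4cccc(F)c4)c(Cl)c3)c2s1` gives a number (52 uM)
- compound 2 `CCCN(CC#Cc1cc2ncnc(Nc3ccc(OCc4cccc(F)c4)c(Cl)c3)c2s1)CCC` gives a limit (> 50 uM)
- compound 3 `CN(C)CC#Cc1cc2ncnc(Nc3ccc(OCc4cccc(F)c4)c(Cl)c3)c2s1` gives a limit (> 50 uM)

Compound 3 stands only at a limit (> 50 uM). Compound 2 and compound 3 both sit at the limit of > 50 uM in this assay, at which 2 of the 3 values shown sit, and give no number to start from. Compound 4 `Fc1cccc(COc2ccc(Nc3ncnc4cc(C#CCN5CCNCC5)sc34)cc2Cl)c1` carries piperazin-1-yl in place of dimethylamino on a saturated chain carbon bound to a triple-bonded carbon in the core of compound 3.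

The nearest changes at this amine are a step that the two limits leave unreadable from compound 2 to compound 3 and a step that the limit leaves unreadable from compound 1 to compound 2 and neither gives a size. No step beyond the scatter, in either direction, is therefore expected in this assay on present data. Within the data shown here, the expectation rests on compound 1 (52 uM), the one number. The estimated change is a number no higher from compound 3 to compound 4 (the limit leaves the size open) for now. For compound 4 the expected value is 50 uM with an estimated range from 20 uM to 80 uM here.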

Compound 4, half-maximal toxic concentration: > 50 uM
Compound 4 ended at the assay's limit; the forecaster's own chance of this, stated with the estimate: 55%; the middle value lies on the limit itself.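

In this assay compound 4 gives > 50 uM, which is a limit and not a number, and its steps from compound 1, compound 2 and compound 3 cannot be read: the limit of > 50 uM in this assay, at which 3 of the 4 values shown sit.

Going by these compounds, the actual tolerated concentrations of compound 2, compound 3 and compound 4 remain open, and so does any difference between their amines.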